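The source may report more compounds than this note shows. Statements on the series, on what has been measured and on what is new or still open speak of the compounds shown alone.

Measured so far in a functional assay on A2780 cells (Homo sapiens) for inhibition, with a stated time of 72 h; a higher number here means a weaker inhibitor, a lower number a stronger inhibitor:
compound 1 `COc1cccc(C(=O)O[C@H]2[C@H]([C@]3(OC(C)=O)CO[C@@H]3CCO)/C(C)=C(/O)C(=O)C3=C(C)[C@@H](OC(=O)[C@H](O)[C@H](C=C(C)C)NC(=O)OC(C)(C)C)C[C@]2(O)C3(C)C)c1` gives 5.7 nM;
compound 2 `CC(=O)O[C@@]1([C@@H]2/C(C)=C(/O)C(=O)C3=C(C)[C@@H](OC(=O)[C@H](O)[C@H](C=C(C)C)NC(=O)OC(C)(C)C)C[C@@](O)([C@H]2OC(=O)c2cccc(F)c2)C3(C)C)CO[C@@H]1CCO` gives 4.9 nM.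

Of these two numbers, compound 2 holds the lower, yet the step of a 1.2-fold lower number from compound 1 to compound 2 (0.07 log units; within the scatter) is within the scatter and separates nothing. Compound 3 `CC(=O)O[C@@]1([C@@H]2/C(C)=C(/O)C(=O)C3=C(C)[C@@H](OC(=O)[C@H](O)[C@H](CC(C)C)NC(=O)OC(C)(C)C)C[C@@](O)([C@H]2OC(=O)c2cccc(F)c2)C3(C)C)CO[C@@H]1CCO` departs from compound 2 by isobutyl in place of 2-methylprop-1-en-1-yl on a saturated chain carbon bound to an amide-type nitrogen and a saturated chain carbon. Within the data shown here, no measured step touches this position; the only one known, a 1.2-fold lower number from compound 1 to compound 2 (0.07 log units; within the scatter), concerns an aromatic carbon and offers no guide. Compound 3 is therefore expected to change little, the estimated step being a 1.2-fold higher number from compound 2 to compound 3 (0.09 log units; within the scatter). Compound 3 is estimated at 6 nM, with a range of 2 nM to 20 nM.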

Compound 3, half-maximal inhibitory concentration: 11.8 nM
For compound 3 the middle estimate is 2.0-fold (0.29 log units) below the measured one, within the range that was stated.
By their numbers in this assay, from the lowest: compounds 2 and 1 (each within the scatter of the next); then compound 3.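

In this assay, among these compounds, isobutyl in place of 2-methylprop-1-en-1-yl gives a 2.4-fold higher number from compound 2 to compound 3 (0.38 log units; beyond the scatter), so this position, which no earlier step touched, responds to the loss of the double bond outside aromatic rings. The step is modest but beyond the scatter, unlike the earlier change on an aromatic carbon. Nothing available explains the shift. The compounds shown leave open how a phenyl group or a longer chain would fare on this carbon. They also leave open whether the same change would hold alongside the methoxy group of compound 1.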